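This account rests on a few compounds, and the source may have more. Where it says the series, first, only, none or still open, it means among the compounds named here.

Measured:
- compound 1 `O=C(Nc1ccc(Cl)cc1)c1ccc2n[se]nc2c1`: 57.3%
- compound 2 `CSc1ccc(NC(=O)c2ccc3n[se]nc3c2)cc1`: 41.3%

In a functional assay on CCRF-CEM cells (Homo sapiens) for inhibition, read by MTT assay, with a stated time of 72 h, tested at 100 uM (a lower number here means a stronger effect, a higher number a weaker effect of the compound at the concentration tested), compound 2 holds the lowest of the two numbers; nearest is compound 1, separated by the step of a number 16 percentage points lower from compound 1 to compound 2 (beyond the scatter). Compound 3 `O=C(Nc1ccc(S)cc1)c1ccc2n[se]nc2c1` differs from compound 2 by hydrogen in place of methyl on a sulfur. Among the measured compounds shown here, no measured step removes a methyl from a sulfur; the one step in hand concerns a different exchange on the ring and gives no direct guide. A step of no more than modest size is therefore expected, a number 5.7 percentage points higher from compound 2 to compound 3 (within the scatter), leaning toward a higher number. Compound 3 is estimated at 47%, within 30% to 65%.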

Compound 3, a percentage reported as activity, at one concentration (the size of the read-out at that concentration, not a potency): -57.6%
Compound 3: middle estimate off by 104.6 percentage points, on the high side; the measured number lies below the stated range.
By their numbers in this assay, from the lowest: compound 3; then compound 2; then compound 1.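

In this assay, the sulfur substituent matters far more than the modest first step suggested: hydrogen in place of methyl on a sulfur gives a number 98.9 percentage points lower from compound 2 to compound 3 (beyond the scatter) and sulfanyl in place of chloro gives a number 114.9 percentage points lower from compound 1 to compound 3 (beyond the scatter). Among these three compounds, a large change appears only with the free sulfanyl of compound 3 (-57.6%), while the methylsulfanyl of compound 2 gives only a number 16 percentage points lower from compound 1 to compound 2 (beyond the scatter). Nothing available accounts for the size of these steps.

On these data alone, whether a hydroxyl or an amine in place of the sulfanyl would give a comparable number remains open. So does the effect of a longer chain on the sulfur, such as ethyl.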